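The compounds below may be only part of what the source reports. "The series", "measured", "known", "first", "only" and "open" are said of these compounds alone.

In a functional assay on the whole organism with Rattus norvegicus as the target (on this read-out higher numbers stand for an effect only at larger amounts of compound and lower numbers for an effect already at smaller amounts), compound 2 (`COCCCc1nc(C(F)(F)F)ccc1CNC(=O)Nc1cccc2[nH]ncc12`) is known only as a limit, > 0.03 umol/kg. Compound 1 (`CC(C)(C)COc1nc(C(F)(F)F)ccc1CNC(=O)Nc1cccc2[nH]ncc12`) is likewise known only as a limit, > 0.1 umol/kg. Compound 3 (`O=C(NCc1ccc(-c2ccccc2)nc1N1CCCCC1)Nc1cccc2[nH]ncc12`) is the only one of the three with a number, 0.037 umol/kg. Going by the values given here, no single-place step ties compound 3 to the other two, so it serves only as a reference point on the scale.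

Compound 4 (`CC(C)(C)CCc1nc(C(F)(F)F)ccc1CNC(=O)Nc1cccc2[nH]ncc12`) has not yet been measured. It differs from compound 2 by tert-butyl in place of methoxymethyl on a saturated chain carbon, two bonds along the chain from an aromatic carbon.

Among the compounds with values here, the only measured step bearing on this change is a step that the two limits leave unreadable from compound 1 to compound 2. Its size cannot be read, so it provides neither a size nor a direction to carry over. No direction of change from compound 2 can therefore be argued, and a further limit for compound 4 is about as likely as a number. The expectation rests mainly on compound 2 and its limit of > 0.03 umol/kg. The expected step, which is poorly constrained, is a step that the limit leaves unreadable from compound 2 to compound 4. For compound 4 the estimate is 0.08 umol/kg, with an expected range from 0.02 umol/kg to 0.3 umol/kg.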

Compound 4, dose for half-maximal effect: 0.1 umol/kg
Estimate against measurement, compound 4: 1.3-fold (0.10 log units) below; the range from low to high includes it.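

In this assay, going by these compounds alone, among the three compounds that share this core, compound 4 with its 3,3-dimethylbutyl chain is the only one that carries a number rather than a limit, so a saturated chain ending in tert-butyl at this place is compatible with a readable dose. Set against the neopentyloxy group on the aromatic carbon, the all-carbon chain gives a number no higher from compound 1 to compound 4 (the limit leaves the size open), and this is the only direction that can be taken from the new steps. Neither new step can be sized, and the comparison with the methoxymethyl end gives no direction, because compound 2 is known only as a limit: the limit of > 0.03 umol/kg in this assay, at which 1 of the 4 values shown sits.

On these data alone, whether tert-butyl or methoxymethyl at this chain carbon gives an effect at the smaller dose stays open, so the two ends of the chain cannot yet be ranked. Also open, as far as these compounds go, is how the dose responds when the chain ends in something quite different, such as a primary amine or a carboxylic acid, or when a longer chain is placed on the same aromatic carbon.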